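Hydroxy for amino at the same aromatic position

The source may report more compounds than this note shows. Statements on the series, on what has been measured and on what is new or still open speak of the compounds shown alone.

Three compounds have been measured in a functional assay on MDA-MB-231 cells (Homo sapiens) for cytotoxicity, read by MTT assay, with a stated time of 48 h; on this read-out higher numbers stand for weaker inhibition and lower numbers for stronger inhibition:

compound 1, `COc1cc(-n2nnnc2-c2ccc(OCC3CC(c4ccc(C(F)(F)F)cc4)=NO3)c(N)c2)cc(OC)c1OC`: 1750 nM
compound 2, `COc1ccc(F)c(C2=NOC(COc3ccc(-c4nnnn4-c4cc(OC)c(OC)c(OC)c4)cc3N)C2)c1`: 2830 nM
compound 3, `COc1ccc(C2=NOC(COc3ccc(-c4nnnn4-c4cc(OC)c(OC)c(OC)c4)cc3N)C2)cc1N`: 3000 nM

Compound 3 gives the highest of these three numbers, but every gap to it is small: a 1.7-fold higher number from compound 1 to compound 3 (0.23 log units; within the scatter) and a 1.1-fold higher number from compound 2 to compound 3 (0.03 log units; within the scatter), and likewise a 1.6-fold higher number from compound 1 to compound 2 (0.21 log units; within the scatter). The three compounds share one core and differ only in the group on the carbon with a double bond to nitrogen, so no ordering among them can be claimed.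

Compound 4, `COc1ccc(C2=NOC(COc3ccc(-c4nnnn4-c4cc(OC)c(OC)c(OC)c4)cc3N)C2)cc1O`, is not yet measured. It differs from compound 3 in one place: hydroxy in place of amino on an aromatic carbon.

Going by the values given here, none of the measured steps touches this part of the core, so nothing tells directly what hydroxy in place of amino does here. Among the compounds with values here, all that the measured steps show is that the only changes tried so far stayed within the scatter. In the absence of a bearing step, the expected change in this assay from compound 3 to compound 4 is no change at the digits printed from compound 3 to compound 4 (within the scatter), that is none beyond the scatter, with a wide range. Compound 4 is therefore estimated at 3000 nM, between 1400 nM and 6500 nM.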

Compound 4, half-maximal inhibitory concentration: 3380 nM
Compound 4: the middle estimate sits 1.1-fold (0.05 log units) below what was measured, and the stated range covers the measured number.
By their numbers in this assay, from the lowest: compounds 1, 2, 3 and 4 (each within the scatter of the next).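

In this assay, going by these compounds alone, hydroxy in place of amino on this aromatic carbon, ortho to a methoxy group, is the first change tried at this position, and its step lies within the scatter (a 1.1-fold higher number from compound 3 to compound 4 (0.05 log units; within the scatter)). The steps that reach compound 4 through the group on the carbon with a double bond to nitrogen also lie within the scatter (a 1.2-fold higher number from compound 2 to compound 4 (0.08 log units; within the scatter); a 1.9-fold higher number from compound 1 to compound 4 (0.29 log units; within the scatter)), so all four compounds still cannot be put in any order. No measurement shown here offers an explanation for this result.

On these data alone, whether a methyl group, an acetamide or a carboxylic acid on this same carbon would give a number beyond the scatter remains open. So does whether hydroxy in place of amino would read the same with a 4-(trifluoromethyl)phenyl group elsewhere on the shared core.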